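Removing the methoxy group from a weak melatonin receptor ligand

The compounds below may be only part of what the source reports. "The series", "measured", "known", "first", "only" and "open" are said of these compounds alone.

Of the compounds shown here, three share one core and have been tested in an assay on CHO cells for displacement of a labelled ligand from melatonin receptor type 1A (Homo sapiens), with a stated time of 120 min; on this read-out higher numbers stand for weaker inhibition and lower numbers for stronger inhibition. Compound 1 `CCC(=O)NCC1CCc2c(OC)cccc2N1C` gives 0.03 nM. Compound 2 `CCNC(=O)NCC1CCc2c(OC)cccc2N1C` gives 5 nM, and the step of a 170-fold higher number from compound 1 to compound 2 (2.22 log units; beyond the scatter) replaced ethyl by ethylamino on the carbonyl carbon. Compound 3 `CCNC(=O)NCC1CCc2c(cccc2OC)N1` gives 480 nM, the highest number of the three, and the step of a 96-fold higher number from compound 2 to compound 3 (1.98 log units; beyond the scatter) put hydrogen in place of methyl on the ring nitrogen. Compound 3 therefore stands furthest from compound 1 and, by a large margin, weakest among the measured compounds in this assay.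

Compound 4 `CCNC(=O)NCC1CCc2ccccc2N1` differs from compound 3 by hydrogen in place of methoxy on an aromatic carbon. Neither measured step touches this part of the molecule: one altered the carbonyl substituent and the other the ring nitrogen, and both were large. Going by the values given here, no measured pair shows what removing the methoxy group does, so the direction can only be inferred from the fact that every change made so far to this core has moved the number a great deal. For compound 4 a further large rise is expected, an 8.3-fold higher number from compound 3 to compound 4 (0.92 log units; beyond the scatter), giving an estimated value of 4000 nM with a range from 600 nM to 25000 nM in this assay.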

Compound 4, inhibition constant: 115 nM
Beside the measured number, compound 4's estimate is 35-fold (1.54 log units) above it; the whole stated range lies above it.
By their numbers in this assay, from the lowest: compound 1; then compound 2; then compound 4; then compound 3.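

In this assay, the methoxy group on this aromatic carbon proves not to be required for inhibition in this series, since the change to hydrogen gives a 4.2-fold lower number from compound 3 to compound 4 (0.62 log units; beyond the scatter) and so stronger inhibition rather than weaker. This is the first step among the compounds shown that lowers the number, whereas a 170-fold higher number from compound 1 to compound 2 (2.22 log units; beyond the scatter) and a 96-fold higher number from compound 2 to compound 3 (1.98 log units; beyond the scatter) both raise it, and it is modest where those two are large, so in the setting of compound 3 this position is less sensitive than the carbonyl substituent or the ring nitrogen were in their own steps. No independent measurement is available to explain why removing the methoxy group strengthens inhibition.

As far as these compounds go, the step was read only with hydrogen on the ring nitrogen and ethylamino on the carbonyl carbon, so it remains open whether the same change would lower the number in compound 1 or compound 2, which carry a methyl group on that nitrogen. From the compounds shown here alone, it is also open how this aromatic carbon would respond to a group other than methoxy or hydrogen, such as ethoxy, hydroxyl or fluorine.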